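Nitro in place of chloro on the pendant phenyl of compound 3

The compounds below may be only part of what the source reports. "The series", "measured", "known", "first", "only" and "open" are said of these compounds alone.

Measured so far:
Compound 1, `COc1ccc2cc(C(C)c3nnc4n3N=C(c3ccc(OC(F)(F)F)cc3)CS4)ccc2c1`: in a functional assay on HCT-116 cells (Homo sapiens) for inhibition, read by sulforhodamine B assay, with a stated time of 72 h (on this read-out higher numbers stand for weaker inhibition and lower numbers for stronger inhibition), compound 1 gives 11700 nM.
Compound 2, `CC(c1ccc(-c2ccccc2)c(F)c1)c1nnc2n1N=C(c1ccccc1)CS2`: in this assay compound 2 gives 9700 nM.
Compound 3, `CC(c1ccc(-c2ccccc2)c(F)c1)c1nnc2n1N=C(c1ccc(Cl)cc1)CS2`: in this assay compound 3 gives 7800 nM.

Compound 3 holds the lowest of the three numbers, but its gap to compound 2 and its gap to compound 1 are both within the scatter, so the three compounds cannot be separated on these data. Going by the values given here, the only one-place step in the set is a 1.2-fold lower number from compound 2 to compound 3 (0.09 log units; within the scatter), and it did not move the read-out beyond the scatter.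

Compound 4, `CC(c1ccc(-c2ccccc2)c(F)c1)c1nnc2n1N=C(c1ccc([N+](=O)[O-])cc1)CS2`, differs from compound 3 by nitro in place of chloro on an aromatic carbon. Among the compounds with values here, no measured step exchanges one substituent for another on this phenyl ring. Within the data shown here, the one step that touches this ring, hydrogen to chloro, stayed within the scatter, and compound 1, which carries a trifluoromethoxy group on the same ring beside a different substituent on the other aryl group, also lies within the scatter of compounds 2 and 3. The data therefore give no reason to expect a step beyond the scatter in this assay in either direction; the expected step is a 1.1-fold higher number from compound 3 to compound 4 (0.04 log units; within the scatter).

Compound 4 is estimated at 8500 nM in this assay, with a range from 3000 nM to 25000 nM.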

Compound 4, half-maximal inhibitory concentration: 7100 nM
Estimate against measurement, compound 4: 1.2-fold (0.08 log units) above; measured number inside the range.
By their numbers in this assay, from the lowest: compounds 4, 3, 2 and 1 (each within the scatter of the next).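

In this assay, going by these compounds alone, the exchange of 4-chlorophenyl for 4-nitrophenyl gives a 1.1-fold lower number from compound 3 to compound 4 (0.04 log units; within the scatter); this is the only measured exchange of one substituent for another on this aromatic carbon, para to a large group. Set against the hydrogen of compound 2, nitro gives a 1.4-fold lower number from compound 2 to compound 4 (0.14 log units; within the scatter), so the hydrogen-to-substituent change at this place now stays within the scatter for two different groups, chloro and nitro, although nitro brings 3 heavy atoms and 2 hydrogen-bond acceptors where chloro brings 1 heavy atom and 0 acceptors. Hydrogen, chloro and nitro at this place therefore cannot be separated in this assay, and no independent measurement is available to account for that.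

Still open, as far as these compounds go, is whether an amine or a carboxylic acid at this place, or a longer chain such as butoxy, would move the number beyond the scatter. Also open, from the compounds shown here alone, is whether nitro would behave in the same way alongside the other aryl group of compound 1, whose ring carries a methoxy group.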